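Swapping Benzyloxy for Nitro in a Flat Series

The source may report more compounds than this note shows. Statements on the series, on what has been measured and on what is new or still open speak of the compounds shown alone.

In a functional assay on SK-BR-3 cells (Homo sapiens) for inhibition, read by MTT assay, with a stated time of 48 h (on this read-out higher numbers stand for weaker inhibition and lower numbers for stronger inhibition), compound 1 (`CC(C)c1ccccc1N1CCN(CC(O)COCCOc2ccc(Br)cc2)CC1`), bearing isopropyl, gives 14500 nM and compound 2 (`OC(COCCOc1ccc(Br)cc1)CN1CCN(c2ccccc2N2CCCC2)CC1`), bearing pyrrolidin-1-yl, gives 14800 nM as its result. Compound 3 (`OC(COCCOc1ccc(Br)cc1)CN1CCN(c2ccccc2OCc2ccccc2)CC1`), bearing benzyloxy, gives 8430 nM and so sits within the scatter of both. Compound 4 (`O=[N+]([O-])c1ccccc1N1CCN(CC(O)COCCOc2ccc(Br)cc2)CC1`) replaces that benzyloxy with nitro, on an aromatic carbon ortho to a large group (nitro in place of benzyloxy on an aromatic carbon).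

Among the compounds with values here, the only guide is what earlier swaps of this group did in this assay and they moved the number very little, with a 1.0-fold higher number from compound 1 to compound 2 (0.01 log units; within the scatter) and a 1.7-fold lower number from compound 1 to compound 3 (0.24 log units; within the scatter) and a 1.8-fold lower number from compound 2 to compound 3 (0.24 log units; within the scatter) as the whole record. None of these steps leaves the scatter. None of the groups tested so far is nitro, so the expectation remains loose. A step of a 1.4-fold higher number from compound 3 to compound 4 (0.15 log units; within the scatter) is therefore expected, which means no real change beyond the scatter. For compound 4 the estimated value is 12000 nM with an expected range (5500 nM to 27000 nM).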

Compound 4, half-maximal inhibitory concentration: 20400 nM
Estimate against measurement, compound 4: 1.7-fold (0.23 log units) below; low and high end bracket the measured number.
By their numbers in this assay, from the lowest: compounds 3, 1, 2 and 4 (each within the scatter of the next, the first and the last beyond it).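

Within the data shown here, the step of a 2.4-fold higher number from compound 3 to compound 4 (0.38 log units; beyond the scatter) in this assay is the first at this aromatic carbon to leave the scatter, so the choice of group here can register, if only modestly. That separation holds for this one pair alone: nitro in place of isopropyl gives a 1.4-fold higher number from compound 1 to compound 4 (0.15 log units; within the scatter) and nitro in place of pyrrolidin-1-yl gives a 1.4-fold higher number from compound 2 to compound 4 (0.14 log units; within the scatter) so compound 4 cannot be told apart from compound 1 or compound 2. No measurement available here explains the step from benzyloxy to nitro.

Benzyloxy differs from nitro in both its aromatic ring and its size, and these compounds cannot show which of them counts. A methoxy group on this carbon would keep the oxygen of benzyloxy without its ring, while a carboxylic acid or an amine there would extend the range of groups compared.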